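Cyclic amine in the amide: clearance outlook for compound 4

The source may report more compounds than this note shows. Statements on the series, on what has been measured and on what is new or still open speak of the compounds shown alone.

Compound 1 `CCCCCOC(=O)N1CCN(C(=O)[C@H](CCC(=O)O)NC(=O)c2cc(N3CCC(C(=O)N(CC)CC)CC3)nc(-c3ccccc3)n2)CC1` stands lowest of the three numbers in an in vivo ADME assay on the whole organism (strain Sprague-Dawley) for pharmacokinetics, with Rattus norvegicus as the target (on this read-out lower numbers stand for slow clearance and higher numbers for fast clearance), giving 6 mL/min/kg. Compound 2 `CCCCCOC(=O)N1CCN(C(=O)[C@H](CCC(=O)O)NC(=O)c2cc(N3CCC(OCCO)CC3)nc(-c3ccccc3)n2)CC1` gives 18 mL/min/kg, and compound 3 `CCCCCOC(=O)N1CCN(C(=O)[C@H](CCC(=O)O)NC(=O)c2cc(N3CCC(COC)CC3)nc(-c3ccccc3)n2)CC1` gives 14 mL/min/kg. Both departures from compound 1 replace the diethylcarbamoyl on the saturated ring carbon with a group that is not an amide: a 3.0-fold higher number from compound 1 to compound 2 (0.48 log units; beyond the scatter) and a 2.3-fold higher number from compound 1 to compound 3 (0.37 log units; beyond the scatter). Between those two, a 1.3-fold lower number from compound 2 to compound 3 (0.11 log units; within the scatter). Compound 4 `CCCCCOC(=O)N1CCN(C(=O)[C@H](CCC(=O)O)NC(=O)c2cc(N3CCC(C(=O)N4CCCC4)CC3)nc(-c3ccccc3)n2)CC1` keeps the amide and differs from compound 1 only in the amine part of it: pyrrolidin-1-yl in place of diethylamino on a carbonyl carbon. Among the measured compounds shown here, no measured step alters the amine of the amide while keeping the carbonyl, so the two steps from compound 1 bear on this change only loosely; they describe the loss of the amide, not a ring closure within it. For compound 4 the expected step is therefore a 1.2-fold higher number from compound 1 to compound 4 (0.07 log units; within the scatter), with no direction beyond the scatter claimed. In this assay compound 4 is estimated at 7 mL/min/kg, with a range from 3 mL/min/kg to 16 mL/min/kg.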

Compound 4, clearance: 2 mL/min/kg
Estimate against measurement, compound 4: 3.5-fold (0.54 log units) above, outside the stated range (below it).
By their numbers in this assay, from the lowest: compound 4; then compound 1; then compounds 3 and 2 (each within the scatter of the next).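

In this assay the amine part of the amide proves to be a responsive place: pyrrolidin-1-yl in place of diethylamino on a carbonyl carbon, a ring closure with no change in carbon or nitrogen content, gives a 3.0-fold lower number from compound 1 to compound 4 (0.48 log units; beyond the scatter) and so moves the number beyond the scatter with the amide kept. Compared with the groups that are not amides, (pyrrolidin-1-yl)carbonyl on a saturated ring carbon widens the separation, with a 7.0-fold lower number from compound 3 to compound 4 (0.85 log units; beyond the scatter) against methoxymethyl and a 9.0-fold lower number from compound 2 to compound 4 (0.95 log units; beyond the scatter) against 2-hydroxyethoxy. Nothing available here accounts for these steps.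

Whether the lower number follows from ring closure as such or from this ring size remains open, as the compounds shown include no azetidin-1-yl, piperidin-1-yl or morpholin-4-yl amide. An ethylamino amide, which would show the effect of removing one ethyl group, is also absent from the compounds shown.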